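A Carbonyl Enters at the Amine Nitrogen

This account rests on a few compounds, and the source may have more. Where it says the series, first, only, none or still open, it means among the compounds named here.

Of the compounds shown here, two sharing one core have been measured in an ADME assay on MT4 cells (Homo sapiens) for cytotoxicity; on this read-out higher numbers stand for lower toxicity in this test and lower numbers for higher toxicity in this test. Compound 1 `C[C@@H](NC(=O)[C@H](CCCNC(=N)N)NC(=O)c1ccc(CN(Cc2ccc(F)cc2)Cc2cccnc2)cc1)c1cccc2ccccc12` gives 37000 nM. For the measured compounds named here, compound 2 `C[C@H](NC(=O)[C@H](CCCNC(=N)N)NC(=O)c1ccc(CN(Cc2ccc(F)cc2)Cc2cccnc2)cc1)c1cccc2ccccc12` gives 41000 nM, the higher of the two numbers, with compound 1 as its only neighbour, and the step of a 1.1-fold higher number from compound 1 to compound 2 (0.04 log units; within the scatter) concerns a single stereocentre; the fact that one of compounds 1 and 2 is drawn with a defined configuration and the other without, at the place where they differ is all the drawings reveal there. Compound 3 `C[C@H](NC(=O)[C@H](CCCNC(=N)N)NC(=O)c1ccc(CN(Cc2cccnc2)C(=O)c2ccc(F)cc2)cc1)c1cccc2ccccc12` has not been measured; it differs from compound 2 by (4-fluorophenyl)carbonyl in place of 4-fluorobenzyl on an amine nitrogen. Going by the values given here, no measured step touches a change of this kind: the one step on hand, a 1.1-fold higher number from compound 1 to compound 2 (0.04 log units; within the scatter), lies within the scatter and involves no exchange of groups at the amine nitrogen. With nothing to point either way, the step of a 1.0-fold lower number from compound 2 to compound 3 (0.01 log units; within the scatter) is expected to stay within the scatter, though with little confidence. Compound 3 is therefore estimated at 40000 nM in this assay, with a range from 12000 nM to 120000 nM.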

Compound 3, half-maximal cytotoxic concentration: 57000 nM
Compound 3: the middle estimate sits 1.4-fold (0.15 log units) below what was measured; the range from low to high includes it.
By their numbers in this assay, from the lowest: compounds 1, 2 and 3 (each within the scatter of the next).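

Exchanging 4-fluorobenzyl for (4-fluorophenyl)carbonyl on the amine nitrogen gives, in this assay, a 1.4-fold higher number from compound 2 to compound 3 (0.14 log units; within the scatter) and so stays inside the usual scatter of this read-out. This is the first exchange of groups at this position among the compounds shown, and it indicates that a carbonyl can stand on this nitrogen, bringing one hydrogen-bond acceptor with it, without a step that can be told from repeat scatter. Nothing available on these compounds bears on why the step has this size.

Still open, from the compounds shown here alone, is whether other groups on this nitrogen, such as an acetyl, a sulfonyl or a plain methyl, would also stay within the scatter. Equally open, going by these compounds, is whether the same exchange would read alike on compound 1, with its stereocentre drawn R.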